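Ester in place of methoxy on the core of compound 1

A few compounds are considered here, and "the series" means these few. Any claim that something is new, unique, unknown or untested is made for them only; others in the source may bear on it.

Measured so far in this assay:
compound 1 `COc1ccc(C(O)(c2cc3cc([N+](=O)[O-])cc(-c4ccccc4)c3o2)c2cncn2C)cc1`: 4970 nM
compound 2 `Cn1cncc1C(O)(c1ccc(C#N)cc1)c1cc2cc([N+](=O)[O-])cc(-c3cccc(C#N)c3)c2o1`: 22.9 nM
compound 3 `Cn1cncc1C(O)(c1ccc(C#N)cc1)c1cc2cc([N+](=O)[O-])cc(-c3ccc(F)cc3)c2o1`: 158 nM

In a functional assay on QG-56 cells (Homo sapiens) for antiproliferative activity (a higher number here means a weaker inhibitor, a lower number a stronger inhibitor), compound 1 stands highest of the three numbers; compound 3 is nearest and compound 2 furthest, both gaps beyond the scatter. Going by the values given here, the single step worked out so far, a 6.9-fold higher number from compound 2 to compound 3 (0.84 log units; beyond the scatter), changes the group on the other aromatic ring and so does not bear on the change to compound 4. Compound 4 `Cn1cncc1C(O)(c1ccc(C(=O)OC(C)(C)C)cc1)c1cc2cc([N+](=O)[O-])cc(-c3ccccc3)c2o1` differs from compound 1 by tert-butoxycarbonyl in place of methoxy on an aromatic carbon. Among the compounds with values here, compounds 2 and 3 carry a nitrile on this ring and give far lower numbers, but they also differ from compound 1 elsewhere, so no step isolates this position. The direction is therefore uncertain; a modest step toward a lower number, a 3.3-fold lower number from compound 1 to compound 4 (0.52 log units; beyond the scatter), is expected, with compound 4 estimated at 1500 nM (range 300 nM to 8000 nM).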

Compound 4, half-maximal inhibitory concentration: 6250 nM
Compound 4: middle estimate off by 4.2-fold (0.62 log units), on the low side; low and high end bracket the measured number.
By their numbers in this assay, from the lowest: compound 2; then compound 3; then compounds 1 and 4 (each within the scatter of the next).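

In this assay, going by these compounds alone, the step of a 1.3-fold higher number from compound 1 to compound 4 (0.10 log units; within the scatter) is the first to isolate this position on the ring para to a large group. Exchanging methoxy for tert-butoxycarbonyl, with its added carbonyl and bulkier chain, gives two compounds that cannot be told apart, so this change alone does not shift the number. No measurement at hand offers an explanation for this result.

Still open, on these data alone, is what a nitrile contributes here on the core of compound 1, apart from the other differences in compounds 2 and 3. A carboxylic acid or an amine at this position also remains untested among the compounds shown.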